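The source may hold more compounds than are shown below. What is called first, only, known or untested is meant among the compounds shown, and "the series" means these compounds.

Measured so far, in a functional assay on Huh-7 cells (Homo sapiens) for cytotoxicity, read by MTT assay, with a stated time of 72 h; on this read-out higher numbers stand for lower toxicity in this test and lower numbers for higher toxicity in this test:
compound 1 `CCS(=O)(=O)N1CCC2(CC1)OOC1(CCCCC1)OO2` gives > 100 ug/mL
compound 2 `CCS(=O)(=O)N1CCC2(CC1)OOC1(CCCCCC1)OO2` gives > 100 ug/mL
compound 3 `CCCS(=O)(=O)N1CCC2(CC1)OOC1(CCCCC1)OO2` gives > 100 ug/mL

Each of these three values is a limit of this assay and not a number. For compound 1 the value > 100 ug/mL is a limit. For compound 2 the value > 100 ug/mL is likewise a limit. For compound 3 the value > 100 ug/mL is also a limit.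

Compound 1 and compound 3 differ by methyl in place of hydrogen on a saturated chain carbon, two bonds along the chain from a sulfonyl sulfur. The step that the two limits leave unreadable from compound 1 to compound 3 cannot be read, since both ends sit at the same limit. The difference between the core of compound 1 and the core of compound 2 is not broken down here.

Compound 4 `CCCS(=O)(=O)N1CCC2(CC1)OOC1(CCCCCC1)OO2` is not yet measured in this assay. It differs from compound 2 by methyl in place of hydrogen on a saturated chain carbon, two bonds along the chain from a sulfonyl sulfur, the same change as that from compound 1 to compound 3, at the same place. Among the compounds with values here, no measured step gives a readable size for this change; what is known is the limit of > 100 ug/mL in this assay, at which 3 of the 3 values shown sit.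

For compound 4 the step that the limit leaves unreadable from compound 2 to compound 4 is expected to be small, and this expectation rests on compound 3 giving > 100 ug/mL after the same change from compound 1. Compound 4 is therefore estimated at 150 ug/mL, between 80 ug/mL and 400 ug/mL, most likely again reported only as a limit.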

Compound 4, half-maximal cytotoxic concentration: > 100 ug/mL
Compound 4: a limit, no number; the forecaster's own chance of this, stated with the estimate: 85%; the middle value is on the limit's open side.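

In this assay compound 4 gives > 100 ug/mL, which is a limit and not a number. Compound 2 also sits at a limit, so no new step can be read between compound 2 and compound 4. The compounds shown leave open whether ethylsulfonyl to propylsulfonyl changes the read-out at all, and where any compound stands past the one thing they establish: the limit of > 100 ug/mL in this assay, at which 4 of the 4 values shown sit.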